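Dithiocarbamate series: pyrazinyl in place of methoxyphenyl

A few compounds are considered here, and "the series" means these few. Any claim that something is new, unique, unknown or untested is made for them only; others in the source may bear on it.

Measured compounds:
compound 1, `O=C(CCSC(=S)NCc1cccnc1)NCc1ccccc1`, > 100000 nM
compound 2, `S=C(NCc1cccnc1)SCCc1nc2ccccc2s1`, 1390 nM
compound 3, `COc1ccc(-c2nnc(CCSC(=S)NCc3cccnc3)o2)cc1`, 2960 nM

The read-out throughout is a functional assay on SK-BR-3 cells (Homo sapiens) for cytotoxicity, read by resazurin assay, with a stated time of 72 h; on this read-out lower numbers stand for stronger inhibition and higher numbers for weaker inhibition. Compound 1 gives only a limit in this assay, (the limit of > 100000 nM in this assay, at which 1 of the 3 values shown sits), so no number stands for it. Among the two numbers, compound 3 holds the higher one; compound 2 sits below it by a gap beyond the scatter, so compound 2 is the stronger of the two measured compounds, while compound 1 cannot be placed.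

The next compound is compound 4, `S=C(NCc1cccnc1)SCCc1nnc(-c2cnccn2)o1`. Relative to compound 3 it carries the change (pyrazin-2-yl in place of 4-methoxyphenyl on an aromatic carbon). Going by the values given here, no measured pair shows a step of this kind, so its size in this assay is not known from the data. The expectation is a small step, most likely a modest rise in the number for compound 4 or none beyond the scatter, as the ring count and the attachment are kept and only the six-membered aromatic ring is exchanged. Compound 4 is therefore estimated at 4000 nM in this assay, with a range from 1500 nM to 12000 nM. The step this estimate means is a 1.4-fold higher number from compound 3 to compound 4 (0.13 log units; within the scatter), which is the expected outcome.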

Compound 4, half-maximal inhibitory concentration: 1290 nM
Compound 4: middle estimate off by 3.1-fold (0.49 log units), on the high side, outside the stated range (below it).
By their numbers in this assay, from the lowest: compounds 4 and 2 (each within the scatter of the next); then compound 3. At a limit, above all of these: compound 1.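

Pyrazin-2-yl in place of 4-methoxyphenyl gives the first single-place step in the series, and it lowers the number beyond the scatter in this assay (a 2.3-fold lower number from compound 3 to compound 4 (0.36 log units; beyond the scatter)). This aromatic carbon of the five-membered aromatic ring with 2 nitrogen and 1 oxygen therefore accepts a six-membered aromatic ring with 2 hetero atoms and fewer heavy atoms without any loss on this read-out, and the 4-methoxyphenyl group is not required for the activity of compound 3. Nothing measured here speaks to the origin of this step.

On these data alone, a single step cannot separate the loss of the methoxy group from the exchange of the ring itself, so unsubstituted phenyl and pyridin-2-yl at this position remain open. Also open, as far as these compounds go, is how a ring bearing an amine or a carboxylic acid would behave here.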